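Thiophene amide series: bromo added to the thiourea phenyl

This account rests on a few compounds, and the source may have more. Where it says the series, first, only, none or still open, it means among the compounds named here.

Measured compounds:
Compound 1 `NC(=O)c1c(NC(=O)c2ccccc2Cl)sc2c1CCN(Cc1cc(Cl)cc(Cl)c1)C2` gives 23700 nM in a functional assay on MKN-74 cells (Homo sapiens) for antiproliferative activity, with a stated time of 24 h; on this read-out lower numbers stand for stronger inhibition and higher numbers for weaker inhibition.
Compound 2 `NC(=O)c1c(NC(=O)c2ccccc2Cl)sc2c1CCN(C(=S)Nc1ccccc1)C2` gives 15600 nM in this assay.

Compound 2 holds the lowest of the two numbers, but its separation from compound 1 is small: a 1.5-fold lower number from compound 1 to compound 2 (0.18 log units; within the scatter). The two compounds are therefore not distinguished on this read-out.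

Compound 3 `NC(=O)c1c(NC(=O)c2ccccc2Cl)sc2c1CCN(C(=S)Nc1ccccc1Br)C2` is the next member and has not been measured in this assay. It differs from compound 2 in one place: bromo in place of hydrogen on an aromatic carbon. Among the measured compounds shown here, none of the measured steps bears on this change. For the measured compounds named here, the only step recorded, from compound 1 to compound 2, swapped the whole group on the amine nitrogen in the ring and stayed within the scatter, which says nothing about a single bromo on the phenyl of the thiourea. Going by the values given here, with no relevant precedent, no step beyond the scatter is expected in either direction.

Compound 3 is accordingly estimated at 13000 nM, with a range from 5000 nM to 35000 nM. The step this estimate implies, a 1.2-fold lower number from compound 2 to compound 3 (0.08 log units; within the scatter), is expected to stay within the scatter.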

Compound 3, half-maximal inhibitory concentration: 10800 nM
Compound 3: the middle estimate sits 1.2-fold (0.08 log units) above what was measured; the measured number falls inside the stated range.
By their numbers in this assay, from the lowest: compounds 3, 2 and 1 (each within the scatter of the next, the first and the last beyond it).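

In this assay, the change from phenyl to 2-bromophenyl on the thiourea gives a 1.4-fold lower number from compound 2 to compound 3 (0.16 log units; within the scatter), so this aromatic carbon, ortho to a large group, accepts a bromo with no separable effect on this read-out. The exchange of the whole group on the amine nitrogen in the ring now gives a 2.2-fold lower number from compound 1 to compound 3 (0.34 log units; beyond the scatter), a modest step beyond the scatter, whereas the version without the bromo gave a 1.5-fold lower number from compound 1 to compound 2 (0.18 log units; within the scatter); with compound 2 and compound 3 themselves not separated, this difference cannot be assigned to the bromo alone. No measurement at hand bears on why these numbers fall as they do.

Still open, from the compounds shown here alone, is whether any group on this aromatic carbon can move the number beyond the scatter, which fluoro, methoxy or an amine in place of the bromo would test. Also open, going by these compounds, is the role of the sulfur in the thiourea, which a urea carrying the same 2-bromophenyl group would address.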